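The source may hold more compounds than are shown below. What is called first, only, known or untested is meant among the compounds shown, and "the series" means these compounds.

The measured compounds in a functional assay on microsomes from liver (Rattus norvegicus) for inhibition; on this read-out lower numbers stand for stronger inhibition and higher numbers for weaker inhibition:
Compound 1 `CN(C)c1ccc(/C=C2\CCc3cc(O)ccc3C2=O)cc1` gives > 20000 nM, which is a limit of the assay.
Compound 2 `CN(C)c1ccc(CC2CCc3cc(O)ccc3C2=O)cc1` gives 1200 nM.
Compound 3 `O=C1/C(=C/c2ccc(-c3ccccc3)cc2)CCc2cc(O)ccc21` gives > 20000 nM, which is a limit of the assay.

Among the measured compounds shown here, compound 2 holds the only plain number among the three, and the limit of > 20000 nM in this assay, at which 2 of the 3 values shown sit, marks where the other two values rest. The difference between the cores of compound 1 and compound 2 is not broken down here. From compound 1 to compound 3 the change is phenyl in place of dimethylamino on an aromatic carbon, and the step that the two limits leave unreadable from compound 1 to compound 3. The unmeasured compound 4 `O=C1c2ccc(O)cc2CCC1Cc1ccc(-c2ccccc2)cc1` differs from compound 2 by phenyl in place of dimethylamino on an aromatic carbon, the same change at the same place. The measured pair gives no readable size for this change, so the expectation for compound 4 rests on what compound 2 shows, namely 1200 nM, with room left for the change to weaken inhibition. Compound 4 is expected to show a step of a 2.1-fold higher number from compound 2 to compound 4 (0.32 log units; beyond the scatter) in this assay, resting on compound 2 at 1200 nM. In this assay compound 4 is expected at about 2500 nM, estimated between 600 nM and 12000 nM.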

Compound 4, half-maximal inhibitory concentration: 800 nM
Beside the measured number, compound 4's estimate is 3.1-fold (0.49 log units) above it; low and high end bracket the measured number.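

In this assay, putting phenyl in place of dimethylamino on the core of compound 2 gives a 1.5-fold lower number from compound 2 to compound 4 (0.18 log units; within the scatter), so on this core the exchange of a group with no ring for one with a six-membered aromatic ring leaves the read-out within the usual scatter. The same change on the core of compound 1 cannot be read, as compound 1 and compound 3 each rest on a limit of the assay and not on a number: the limit of > 20000 nM in this assay, at which 2 of the 4 values shown sit. The change therefore has one readable size on one core, and nothing shown says whether that size carries over to the other core, so the series offers no test of transfer in either direction.

As far as these compounds go, it remains open how a methoxy group or a carboxylic acid would read at the same place on the core of compound 2. From the compounds shown here alone, it also remains open whether any such group on the core of compound 1 would give a plain number.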